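This account rests on a few compounds, and the source may have more. Where it says the series, first, only, none or still open, it means among the compounds named here.

Measured so far:
compound 1 `O=C(CN1CCCC1)Nc1ccc(-c2nc3cc(C(F)(F)F)ccc3[nH]2)cc1`: 18000 nM
compound 2 `Cn1c(-c2ccc(NC(=O)CN3CCN(c4ccccc4)CC3)cc2)nc2cc(C(F)(F)F)ccc21`: 1500 nM

In an ADME assay on MT4 cells (Homo sapiens) for cytotoxicity, read by MTT assay, with a stated time of 96 h (on this read-out higher numbers stand for lower toxicity in this test and lower numbers for higher toxicity in this test), compound 1 gives the higher of the two numbers, and compound 2 gives a lower number, with a gap between them that lies beyond the usual scatter. Compound 3 `O=[N+]([O-])c1ccc(-c2nc3cc(C(F)(F)F)ccc3[nH]2)cc1` has not yet been measured. It differs from compound 1 in one place: nitro in place of (((pyrrolidin-1-yl)methyl)carbonyl)amino on an aromatic carbon. Nothing measured here shows what this swap does in this assay. The step from compound 1 to compound 3 is expected to be modest, toward a lower number, roughly a 1.8-fold lower number from compound 1 to compound 3 (0.26 log units; within the scatter). Compound 3 is estimated at 10000 nM, with a likely range from 2500 nM to 40000 nM.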

Compound 3, half-maximal cytotoxic concentration: 6000 nM
Compound 3: middle estimate off by 1.7-fold (0.22 log units), on the high side; the range from low to high includes it.
By their numbers in this assay, from the lowest: compound 2; then compound 3; then compound 1.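

In this assay, putting nitro in place of (((pyrrolidin-1-yl)methyl)carbonyl)amino on this aromatic carbon gives a 3.0-fold lower number from compound 1 to compound 3 (0.48 log units; beyond the scatter), so this position does influence the read-out. The smaller group, which has no ring, goes with higher toxicity in this test. The swap changes several features at once, and no supporting data point to which one matters.

Still open, on these data alone, is how an amine or a carboxylic acid on the same carbon would read. A longer chain ending in pyrrolidine could also show whether the size of the group tracks with the read-out.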